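The source may hold more compounds than are shown below. What is called first, only, known or untested is meant among the compounds shown, and "the series" means these compounds.

Measured compounds:
- compound 1, `CS(=O)(=O)c1ccc(C(=O)N2CCC(N(C3CC3)S(=O)(=O)c3cccc(C(F)(F)F)c3)CC2)cc1`: "not determined" (no result reported) in an assay on cells for inhibition of Voltage-dependent L-type calcium channel subunit alpha-1C (Homo sapiens), read by FLIPR and calcium flux, tested at 1 uM; a lower number here means a weaker effect, a higher number a stronger effect of the compound at the concentration tested
- compound 2, `O=C(c1cccc(OC(F)(F)F)c1)N1CCC(N(C2CC2)S(=O)(=O)c2cccc(C(F)(F)F)c2)CC1`: 60%

Among the measured compounds shown here, compound 2 is the only compound here with a number in this assay; compound 1 shares the core but carries no result there, so nothing can be said about how the two compare. Compound 2 therefore stands alone as the reference point, with 60% giving the inhibition it produces at the test concentration.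

Compound 3, `NC(=O)c1ccccc1C(=O)N1CCC(N(C2CC2)S(=O)(=O)c2cccc(C(F)(F)F)c2)CC1`, is the unmeasured analogue. It differs from compound 2 in a single place: 2-carbamoylphenyl in place of 3-(trifluoromethoxy)phenyl on a carbonyl carbon. For the measured compounds named here, the group that leaves and the group that enters are counted in that description, and no measured pair in this set shows what such a swap does in this assay.

Going by the values given here, with no comparable step on record, the estimate for compound 3 rests only on compound 2 and on the extent of the change. The change is expected to lower the read-out by a modest amount, beyond the usual scatter, as a step of a number 20 percentage points lower from compound 2 to compound 3 (beyond the scatter). Compound 3 is accordingly estimated to give 40% in this assay, within a range from 10% to 70%.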

Compound 3, a percentage reported as inhibition, at one concentration (the size of the read-out at that concentration, not a potency): 11%
Estimate against measurement, compound 3: 29 percentage points above; the range from low to high includes it.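

In this assay, among the compounds shown here, putting 2-carbamoylphenyl in place of 3-(trifluoromethoxy)phenyl on a carbonyl carbon gives a number 49 percentage points lower from compound 2 to compound 3 (beyond the scatter), the first evidence that the read-out at this position depends strongly on the group it carries. The swap changes several things at once: the entering group has fewer heavy atoms, brings nitrogen and loses the three fluorines, adds a hydrogen-bond donor and a double bond outside the aromatic ring, and carries its substituent at a different numbered ring position, so this single step cannot assign the drop to any one of these differences. Nothing in the data shown explains the size of the step.

The compounds shown leave open whether the carbamoyl group itself or its placement at the 2-position of the phenyl ring goes with the lower read-out, since no compound separates the two. They also leave open how the read-out would respond to a plain phenyl ring, or to a phenyl ring bearing a carboxylic acid or an amine, on the same carbonyl carbon.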